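Arylacetamide ethers on a thiazolidinedione core: amide-aryl swap

The compounds below may be only part of what the source reports. "The series", "measured", "known", "first", "only" and "open" are said of these compounds alone.

Measured so far:
compound 1, `Cc1cc(Br)ccc1NC(=O)COc1ccc2cc(/C=C3/SC(=O)NC3=O)ccc2c1`, 7400 nM
compound 2, `Cc1cccc2sc(NC(=O)COc3ccc4cc(/C=C5/SC(=O)NC5=O)ccc4c3)nc12`, 5800 nM

Both numbers come from an assay on isolated protein for inhibition of histone deacetylase 8 (Homo sapiens), with a stated time of 1 h; a higher number here means a weaker inhibitor, a lower number a stronger inhibitor. Among the measured compounds shown here, compound 2 holds the lowest of the two numbers, but its only neighbour is compound 1, and the difference a 1.3-fold lower number from compound 1 to compound 2 (0.11 log units; within the scatter) lies within the scatter; on these data compound 2 and compound 1 cannot be told apart.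

The next compound, compound 3, `O=C(COc1ccc2cc(/C=C3/SC(=O)NC3=O)ccc2c1)Nc1c(F)cc(F)cc1Br`, keeps the shared core and the ether-linked amide and changes only the aryl group on the amide-type nitrogen: 2-bromo-4,6-difluorophenyl in place of 4-methyl-1,3-benzothiazol-2-yl on an amide-type nitrogen.

For the measured compounds named here, the one step on record that bears on this position is a 1.3-fold lower number from compound 1 to compound 2 (0.11 log units; within the scatter), where a substituted phenyl was replaced by the benzothiazolyl group without a change beyond the scatter. Compound 3 goes back to a substituted phenyl, now carrying bromine and two fluorines instead of bromine and a methyl. Going by the values given here, no measured step separates these two phenyl patterns, so nothing in the data predicts a shift in this assay beyond the scatter in either direction.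

Compound 3 is therefore expected to land at about 7000 nM, with a range of 3000 nM to 16000 nM, which corresponds to an expected step of a 1.2-fold higher number from compound 2 to compound 3 (0.08 log units; within the scatter).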

Compound 3, half-maximal inhibitory concentration: > 50000 nM
Compound 3: no number, only a limit (the forecaster's own chance of this, stated with the estimate: 5%); at least 7.1-fold (0.85 log units) between middle value and limit.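

In this assay compound 3 gives no number, only a limit: the limit of > 50000 nM in this assay, at which 1 of the 3 values shown sits.

The change to 2-bromo-4,6-difluorophenyl gives an at least 8.6-fold higher number from compound 2 to compound 3 (0.93 log units; beyond the scatter), and set against the other substituted phenyl it gives an at least 6.7-fold higher number from compound 1 to compound 3 (0.82 log units; beyond the scatter). The group on the amide-type nitrogen is therefore not indifferent, as the earlier pair alone might have suggested: 4-methyl-1,3-benzothiazol-2-yl and 4-bromo-2-methylphenyl could not be told apart, yet compound 1 and compound 3, which both carry a substituted phenyl, differ beyond the scatter, so the substituent pattern on that phenyl matters here and not just the presence of a phenyl.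

The compounds shown leave open how far compound 3 lies past its limit and which part of the 2-bromo-4,6-difluorophenyl pattern goes with the weaker inhibition, since the fluorines enter and the methyl leaves in the same step. A plain phenyl group, or a phenyl carrying only bromine, on the same amide-type nitrogen would bear on that question.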